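Series notes: cyclohexylmethyl for 1-acetylpiperidin-4-yl

A few compounds are considered here, and "the series" means these few. Any claim that something is new, unique, unknown or untested is made for them only; others in the source may bear on it.

Compound 1 `CC(=O)N1CCC(n2c(-c3ccc(OCc4c(-c5c(Cl)cccc5Cl)noc4C(C)C)cc3)nc3ccc(C(=O)O)cc32)CC1` was run in an assay on HEK-293T cells for antagonist activity at vitamin D3 receptor (Homo sapiens), read by a luciferase reporter, with a stated time of 24 h (a higher number here means a weaker inhibitor, a lower number a stronger inhibitor), and gives only a limit, > 10000 nM. Compound 1 thus stands at the limit of > 10000 nM in this assay, at which 1 of the 2 values shown sits, with no numeric value. Among the measured compounds shown here, compound 2 `CC(C)c1onc(-c2c(Cl)cccc2Cl)c1COc1ccc(-c2nc3ccc(C(=O)O)cc3n2C)cc1Cl` gives 2450 nM in this assay, the only number in the set. Compound 3 `CC(C)c1onc(-c2c(Cl)cccc2Cl)c1COc1ccc(-c2nc3ccc(C(=O)O)cc3n2CC2CCCCC2)cc1` is not yet measured; it differs from compound 1 by cyclohexylmethyl in place of 1-acetylpiperidin-4-yl on an aromatic nitrogen. For the measured compounds named here, no measured step sizes this change, so the direction rests on the single value of compound 2 in this assay. Compound 3 is expected to give about 3000 nM, within 800 nM to 15000 nM, an estimated step of an at least 3.3-fold lower number from compound 1 to compound 3 (0.52 log units; beyond the scatter) that would turn the limit into a number.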

Compound 3, half-maximal inhibitory concentration: 346 nM
Estimate against measurement, compound 3: 8.7-fold (0.94 log units) above; measured number outside the range, below it.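

On the aromatic nitrogen, cyclohexylmethyl in place of 1-acetylpiperidin-4-yl gives an at least 28-fold lower number from compound 1 to compound 3 (1.46 log units; beyond the scatter) in this assay, which shows that the group at this position can move the read-out well beyond the scatter. The change alters the ring atoms, the acetyl and the link to the nitrogen together, so the step cannot be assigned to any one of them. The value of compound 1 is a limit, so the step is a bound and not a size: the limit of > 10000 nM in this assay, at which 1 of the 3 values shown sits.

Open, going by these compounds, is whether a free piperidin-4-yl amine or a longer chain such as hexyl on this nitrogen would keep the number of compound 3.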